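A Ring Oxygen Enters the Amide of Compound 2

The source may report more compounds than this note shows. Statements on the series, on what has been measured and on what is new or still open speak of the compounds shown alone.

Of the compounds shown here, two have been measured in an assay on HEK293 cells for positive allosteric modulation of metabotropic glutamate receptor 5 (Homo sapiens), read by FLIPR, with a stated time of 1 h; on this read-out lower numbers stand for an effect already at smaller amounts and higher numbers for an effect only at larger amounts of compound. Compound 1 `CC1CC1C(=O)N1CCc2nc(C#Cc3ccccc3)sc2C1` gives 9.4 nM in this assay, and compound 2 `O=C(C1CCCC1)N1CCc2nc(C#Cc3ccccc3)sc2C1` gives 19 nM. Going by the values given here, the only step between them, a 2.0-fold higher number from compound 1 to compound 2 (0.31 log units; beyond the scatter), places compound 2 at the higher of the two numbers, with compound 1 as its sole neighbour.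

Compound 3 `O=C(C1CCCO1)N1CCc2nc(C#Cc3ccccc3)sc2C1` differs from compound 2 in one place: oxolan-2-yl in place of cyclopentyl on a carbonyl carbon. Among the compounds with values here, no measured step bears directly on this change. The step from compound 1 to compound 2 swaps one ring of carbon only for another ring of carbon only and says nothing about placing an oxygen in the ring. With so little to lean on, compound 3 is expected to land near compound 2, perhaps at a somewhat higher number. The expected step is a 1.6-fold higher number from compound 2 to compound 3 (0.20 log units; within the scatter). Compound 3 is estimated at 30 nM, with a range from 8 nM to 120 nM.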

Compound 3, half-maximal effective concentration: 790 nM
Compound 3: the middle estimate sits 26-fold (1.42 log units) below what was measured; measured number outside the range, above it.
By their numbers in this assay, from the lowest: compound 1; then compound 2; then compound 3.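

In this assay, oxolan-2-yl in place of cyclopentyl on a carbonyl carbon brings a 42-fold higher number from compound 2 to compound 3 (1.62 log units; beyond the scatter), far larger than the carbon-only ring change that gave a 2.0-fold higher number from compound 1 to compound 2 (0.31 log units; beyond the scatter). Both rings are five-membered with 5 heavy atoms, so this position responds strongly to a change that leaves the ring size and heavy-atom count unchanged, and oxolan-2-yl in place of 2-methylcyclopropyl gives an 84-fold higher number from compound 1 to compound 3 (1.92 log units; beyond the scatter). No supporting measurement here accounts for the size of this change.

The compounds shown leave open whether the large step is specific to oxygen at this ring position, as oxolan-3-yl would test. They also leave open how a ring nitrogen, as in pyrrolidin-2-yl, or an open chain such as methoxymethyl would behave in this place.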